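The source may report more compounds than this note shows. Statements on the series, on what has been measured and on what is new or still open speak of the compounds shown alone.

Measured compounds:
compound 1 `COc1cc2nc(Cl)nc(NS(=O)(=O)c3ccccc3)c2cc1OC`, 6.06 ug/mL
compound 2 `COc1cc2nc(Cl)nc(NS(=O)(=O)c3cccc(C(F)(F)F)c3)c2cc1OC`, 59.1 ug/mL
compound 3 `COc1cc2nc(N3CCCC3)nc(NS(=O)(=O)c3ccc(C)cc3)c2cc1OC`, 8.61 ug/mL

In a functional assay on U-937 cells (Homo sapiens) for cytotoxicity, read by MTT assay, with a stated time of 24 h (on this read-out lower numbers stand for stronger inhibition and higher numbers for weaker inhibition), compound 1 gives the lowest of the three numbers. Compound 3 sits within the scatter of it, so no order between those two can be drawn; compound 2 lies clearly further away, with a 9.8-fold higher number from compound 1 to compound 2 (0.99 log units; beyond the scatter).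

Compound 4 `COc1ccc(S(=O)(=O)Nc2nc(Cl)nc3cc(OC)c(OC)cc23)cc1C` shares the core of compound 1 and differs from it in one place: 4-methoxy-3-methylphenyl in place of phenyl on a sulfonyl sulfur.

Within the data shown here, the only single-point step among the measured compounds that bears on this change is the one from compound 1 to compound 2, where a group was added to the phenyl on the sulfonyl sulfur, and it gave a 9.8-fold higher number from compound 1 to compound 2 (0.99 log units; beyond the scatter). Among the measured compounds shown here, the group entering in compound 4 is not the same, and no measured pair isolates a methoxy or a methyl on this phenyl, so the comparison is loose. Compound 3, carrying a methyl on its phenyl together with a different group on the core, gives 8.61 ug/mL, near compound 1.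

Taken together, compound 4 is expected to show a moderately higher number than compound 1, estimated as a 2.0-fold higher number from compound 1 to compound 4 (0.30 log units; within the scatter). The value expected for compound 4 in this assay is 12 ug/mL, within a range from 4 ug/mL to 40 ug/mL.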

Compound 4, half-maximal inhibitory concentration: 41.1 ug/mL
For compound 4 the middle estimate is 3.4-fold (0.53 log units) below the measured one; the whole stated range lies below it.
By their numbers in this assay, from the lowest: compounds 1 and 3 (each within the scatter of the next); then compounds 4 and 2 (each within the scatter of the next).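

In this assay, 4-methoxy-3-methylphenyl in place of phenyl on a sulfonyl sulfur gives a 6.8-fold higher number from compound 1 to compound 4 (0.83 log units; beyond the scatter). The rise seen with trifluoromethyl is thus no longer a single case: with the core of compound 1 kept, both substituted phenyls, in compound 2 and compound 4, stand beyond the scatter from the plain phenyl and within the scatter of each other, although they carry different groups. No measurement given here accounts for this rise.

The compounds shown do not separate the part played by the methoxy from that of the methyl on this phenyl. On these data alone, it also remains open whether any group on this phenyl, such as an amine or a carboxylic acid, would leave the number near that of compound 1.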